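The source may hold more compounds than are shown below. What is called first, only, known or untested is meant among the compounds shown, and "the series" means these compounds.

Measured compounds:
Compound 1, `CC(/C=C/CC(C)CCCC(C)C)=C\C(=O)Oc1ccccc1`, gives 7.67.
Compound 2, `CCCOC(=O)/C=C(C)/C=C/CC(C)CCCC(C)(C)OC`, gives 6.08.
Compound 3, `CCOC(=O)/C=C(C)/C=C/CC(C)CCCC(C)(C)Cl`, gives 6.44.

All three numbers come from a physicochemical assay for lipophilicity; a higher number here means a more lipophilic compound, a lower number a more polar compound. Among them compound 1 stands highest. Compound 3 comes nearest to it, with a number that is lower by more than the usual scatter, and compound 2 lies furthest away, lower still and likewise beyond the scatter.

The next compound, compound 4, `CC(/C=C/CC(C)CCCC(C)C)=C\C(=O)NC(C)C`, has not yet been measured in this assay. It differs from compound 1 in one place: isopropylamino in place of phenoxy on a carbonyl carbon. Among the compounds with values here, no pair among the measured compounds shows this same change, so there is no measured step to lean on, and the expectation rests on the change itself. A clear fall in this assay is expected, well beyond the scatter, rather than no change or a rise. The step from compound 1 to compound 4 is expected to be a number 2.07 log units lower from compound 1 to compound 4 (beyond the scatter). Compound 4 is therefore estimated at 5.6, with a likely range from 5 to 6.3.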

Compound 4, partition coefficient: 5.65
The estimate for compound 4 lay 0.05 log units below the measured number; the measured number falls inside the stated range.
By their numbers in this assay, from the lowest: compound 4; then compound 2; then compound 3; then compound 1.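

Within the data shown here, this is the only step between compounds that differ in one place, and it shows that the group on this carbonyl carbon has a strong hold on the number in this assay: with isopropylamino in place of phenoxy, the result is a number 2.02 log units lower from compound 1 to compound 4 (beyond the scatter) and the shift is large. The change is a bundled one, since the six-membered aromatic ring goes, the group gets smaller, and oxygen gives way to nitrogen carrying a hydrogen-bond donor, so this single step cannot divide the fall among those differences. Nothing shown here gives an independent measurement that would explain the fall.

Going by these compounds, an anilino group on the same carbonyl carbon would keep the aromatic ring while bringing in the nitrogen, and where it would fall remains open. So does the result for a dimethylamino group, which has no hydrogen on its nitrogen.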